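The source may report more compounds than this note shows. Statements on the series, on what has been measured and on what is new or still open speak of the compounds shown alone.

Measured so far in a functional assay on BGC-823 cells (Homo sapiens) for inhibition, read by MTT assay, tested at 10 uM; on this read-out higher numbers stand for more inhibition at the one concentration tested (going by the name of the read-out) and lower numbers for less inhibition:
- compound 1, `Cc1ccc2c(c1)CCN2S(=O)(=O)c1ccc(-c2cnc(C3CC3)o2)cc1`: 79.1%
- compound 2, `O=[N+]([O-])c1ccc2c(c1)CCN2S(=O)(=O)c1ccc(-c2cnc(C3CC3)o2)cc1`: 87.5%

Compound 2 stands alongside compound 1, the two separated only by a number 8.4 percentage points higher from compound 1 to compound 2 (within the scatter). Compound 3 is `N#Cc1ccc2c(c1)CCN2S(=O)(=O)c1ccc(-c2cnc(C3CC3)o2)cc1`; the change from compound 2 is cyano in place of nitro on an aromatic carbon. For the measured compounds named here, the one measured step, nitro in place of methyl on an aromatic carbon, stayed within the scatter, and no step from nitro to cyano has been measured, so no movement beyond the scatter is expected in this assay. Compound 3 is estimated at 82% (range 66% to 94%), a step of a number 5.5 percentage points lower from compound 2 to compound 3 (within the scatter) expected from compound 2.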

Compound 3, a percentage reported as inhibition, at one concentration (the size of the read-out at that concentration, not a potency): 29.6%
The estimate for compound 3 lay 52.4 percentage points above the measured number, outside the stated range (below it).
By their numbers in this assay, from the lowest: compound 3; then compounds 1 and 2 (each within the scatter of the next).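

In this assay this aromatic carbon proves sensitive to the group it carries: cyano in place of nitro gives a number 57.9 percentage points lower from compound 2 to compound 3 (beyond the scatter) while cyano in place of methyl gives a number 49.5 percentage points lower from compound 1 to compound 3 (beyond the scatter) on the same carbon. Compound 1 and compound 2 lie within the scatter of each other, so only cyano separates from the other two groups here. Nothing available explains this loss.

Still open, on these data alone, is how other groups behave at this carbon. An amine, a carboxylic acid or chlorine there would show whether compound 3 stands alone in the series.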